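Removing a Pyridine Methyl in Two Thiosemicarbazide Cores

The source may report more compounds than this note shows. Statements on the series, on what has been measured and on what is new or still open speak of the compounds shown alone.

The study compares three measured compounds and one that awaits measurement. Compound 1 `Cc1ccnc(/C(N)=N/NC(=S)N2CCN(c3ccccn3)CC2)c1` has the core bearing a pyridinyl-piperazine; compound 3 `Cc1cccc(/C(N)=N/NC(=S)N2CCCCC2)n1` and compound 2 `N/C(=N\NC(=S)N1CCCCC1)c1ccccn1` share a piperidine core. The difference between the two cores is not broken down here. In a functional assay on HeLa cells (Homo sapiens) for cytotoxicity, read by MTT assay, with a stated time of 72 h, tested at 1 uM (on this read-out higher numbers stand for more inhibition of growth at the one concentration tested and lower numbers for less inhibition of growth), compound 1 gives 40.4%, compound 3 gives 27% and compound 2 gives 15.5%. Compound 1 therefore stands highest of the three, with compound 3 nearest and compound 2 furthest.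

The step from compound 3 to compound 2 is hydrogen in place of methyl on an aromatic carbon, which gave a number 11.5 percentage points lower from compound 3 to compound 2 (beyond the scatter). Compound 4 `N/C(=N\NC(=S)N1CCN(c2ccccn2)CC1)c1ccccn1` arises from compound 1 by the same kind of change, (hydrogen in place of methyl on an aromatic carbon); the place differs in that the methyl of compound 3 sits next to the ring nitrogen, whereas in compound 1 it sits opposite the ring nitrogen.

Resting on the drop seen in a number 11.5 percentage points lower from compound 3 to compound 2 (beyond the scatter), compound 4 is expected to fall below compound 1 by a step of about a number 11.4 percentage points lower from compound 1 to compound 4 (beyond the scatter). The estimated value for compound 4 in this assay is 29%, expected to lie between 17% and 41%.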

Compound 4, percent growth inhibition at one concentration: 16.7%
Estimate against measurement, compound 4: 12.3 percentage points above; the whole stated range lies above it.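

In this assay, taking the methyl away once more gives a lower number, here a number 23.7 percentage points lower from compound 1 to compound 4 (beyond the scatter), as the 4-methylpyridin-2-yl group becomes pyridin-2-yl. Set beside the earlier step, the change points the same way on both cores, and the two steps cannot be told apart in size: the same change on two cores in this assay, a number 11.5 percentage points lower (beyond the scatter) from compound 3 to compound 2 and a number 23.7 percentage points lower (beyond the scatter) from compound 1 to compound 4, 12.2 percentage points apart, within the scatter of two such steps This shows that in these two pairs the methyl-to-hydrogen change carries over from one core to the other in direction, but two pairs do not establish a rule for the series, and since the methyl sits opposite the ring nitrogen in compound 1 and at another place in compound 3, the effect of its place cannot be separated from that of the core.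

The compounds shown leave open whether a methyl opposite the ring nitrogen would give a similar step on the core of compound 3. They also leave open how an ethyl group, a methoxy group or a chlorine atom would read in place of the methyl on either core.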